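Ortho substituent swap on the aryl arm of the series

The source may hold more compounds than are shown below. What is called first, only, known or untested is meant among the compounds shown, and "the series" means these compounds.

Compound 1 `Cc1nn(-c2nc(-c3ccc(Cl)c(Cl)c3)c(SC(C)C)s2)c(C(=O)O)c1-c1cnn(C)c1` gives 6800 nM in a functional assay on BJAB cells (Homo sapiens) for antiproliferative activity, with a stated time of 4 days; on this read-out lower numbers stand for an effect already at smaller amounts and higher numbers for an effect only at larger amounts of compound. Compound 2 `COc1ccccc1-c1c(C)nn(-c2nc(-c3ccc(Cl)c(Cl)c3)c(SC(C)C)s2)c1C(=O)O` gives 14700 nM, the higher of the two numbers; the step of a 2.2-fold higher number from compound 1 to compound 2 (0.33 log units; beyond the scatter) is modest. Among the measured compounds shown here, compound 3 `Cc1nn(-c2nc(-c3ccc(Cl)c(Cl)c3)c(SC(C)C)s2)c(C(=O)O)c1-c1ccccc1Cl` is not yet measured; the change chloro in place of methoxy on an aromatic carbon has no measured counterpart here, as the one step known concerns a different group. With nothing to anchor a direction, compound 3 is expected near compound 2, at 11000 nM with a range of 4000 nM to 30000 nM. The estimated step of a 1.3-fold lower number from compound 2 to compound 3 (0.13 log units; within the scatter) is expected to stay within the usual scatter.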

Compound 3, half-maximal effective concentration: 13100 nM
For compound 3 the middle estimate is 1.2-fold (0.08 log units) below the measured one; the range from low to high includes it.
By their numbers in this assay, from the lowest: compounds 1, 3 and 2 (each within the scatter of the next, the first and the last beyond it).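

In this assay, chloro in place of methoxy on the aromatic carbon ortho to a large group leaves the number unchanged within the scatter (a 1.1-fold lower number from compound 2 to compound 3 (0.05 log units; within the scatter)). The 2-chlorophenyl group also stays within the scatter of 1-methyl-1H-pyrazol-4-yl (a 1.9-fold higher number from compound 1 to compound 3 (0.28 log units; within the scatter)), whereas 2-methoxyphenyl does not (a 2.2-fold higher number from compound 1 to compound 2 (0.33 log units; beyond the scatter)). No supporting data bear on the reason for these results.

As far as these compounds go, whether an amine or a nitrile at this position would shift the number beyond the scatter remains open.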